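Hydroxyl Added to the Chlorophenyl Arm of a Bis-Benzylidene Ketone

The source may hold more compounds than are shown below. What is called first, only, known or untested is meant among the compounds shown, and "the series" means these compounds.

Compound 1 `COc1cccc(/C=C2\CCC/C(=C\c3ccccc3Cl)C2=O)c1OC`: 11700 nM
Compound 2 `COc1cccc(/C=C2\CCC/C(=C\c3cc(Cl)cc(Cl)c3)C2=O)c1OC`: 6100 nM
Compound 3 `COc1ccc(/C=C2\CCC/C(=C\c3ccc(Cl)cc3)C2=O)cc1OC`: 4800 nM

In a functional assay on HT-1080 cells (Homo sapiens) for cytotoxicity, read by MTT assay, with a stated time of 72 h (a higher number here means a weaker inhibitor, a lower number a stronger inhibitor), compound 3 gives the lowest of the three numbers; compound 2 lies within the scatter of it, while compound 1 lies beyond it. Compound 4 `COc1ccc(/C=C2\CCC/C(=C\c3ccc(O)c(Cl)c3)C2=O)cc1OC` differs from compound 3 by 3-chloro-4-hydroxyphenyl in place of 4-chlorophenyl on a double-bonded chain carbon bound to a double-bonded ring carbon. For the measured compounds named here, only one step between measured compounds is available, a 1.9-fold lower number from compound 1 to compound 2 (0.28 log units; within the scatter), and it concerns a different exchange of the chlorophenyl group, so it bears only loosely on this change. Going by the values given here, no measured pair shows the effect of a hydroxyl on that ring. Compound 4 is therefore expected to stay close to compound 3, with a step of a 1.2-fold lower number from compound 3 to compound 4 (0.08 log units; within the scatter), and its estimated value is 4000 nM, ranging from 1500 nM to 12000 nM.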

Compound 4, half-maximal inhibitory concentration: 7600 nM
For compound 4 the middle estimate is 1.9-fold (0.28 log units) below the measured one; the range from low to high includes it.
By their numbers in this assay, from the lowest: compounds 3, 2, 4 and 1 (each within the scatter of the next, the first and the last beyond it).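

In this assay, for the compounds shown here, the exchange of 4-chlorophenyl for 3-chloro-4-hydroxyphenyl on a double-bonded chain carbon bound to a double-bonded ring carbon gives a 1.6-fold higher number from compound 3 to compound 4 (0.20 log units; within the scatter), the first reading at this place of a ring carrying a hydroxyl. This place therefore holds both rings with no difference beyond the scatter, at least in this one pair. Nothing given here explains the result.

As far as these compounds go, the exchange alters the ring in two ways at once, so the share of the hydroxyl alone remains open. From the compounds shown here alone, how an amine or a carboxylic acid would read on this ring also remains open.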